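Swapping nitro for fluoro on an aromatic ring

The source may report more compounds than this note shows. Statements on the series, on what has been measured and on what is new or still open speak of the compounds shown alone.

- Compound 1 `CC1=CC[C@H]2[C@H](CC[C@]2(C)O)C(C)(C)[C@@H]1CC[C@H]1[C@]2(C)CC[C@H](OCc3ccccc3)C(C)(C)O[C@H]2CC[C@@]1(C)O` gives 29100 nM
- Compound 2 `CC1=CC[C@H]2[C@H](CC[C@]2(C)O)C(C)(C)[C@@H]1CC[C@H]1[C@]2(C)CC[C@H](OC(=O)c3ccc(F)cc3)C(C)(C)O[C@H]2CC[C@@]1(C)O` gives 11300 nM
- Compound 3 `CC1=CC[C@H]2[C@H](CC[C@]2(C)O)C(C)(C)[C@@H]1CC[C@H]1[C@]2(C)CC[C@H](OC(=O)c3ccccc3[N+](=O)[O-])C(C)(C)O[C@H]2CC[C@@]1(C)O` gives 38700 nM

All three values come from a functional assay on MDA-MB-231 cells (Homo sapiens) for antiproliferative activity, read by MTT assay, with a stated time of 72 h; on this read-out lower numbers stand for stronger inhibition and higher numbers for weaker inhibition. Compound 3 has the highest number of the three, but the data do not separate it from its nearest neighbour: a 1.3-fold higher number from compound 1 to compound 3 (0.12 log units; within the scatter). The gap to the other compound is clearer: a 3.4-fold higher number from compound 2 to compound 3 (0.53 log units; beyond the scatter).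

Compound 4 `CC1=CC[C@H]2[C@H](CC[C@]2(C)O)C(C)(C)[C@@H]1CC[C@H]1[C@]2(C)CC[C@H](OC(=O)c3ccccc3F)C(C)(C)O[C@H]2CC[C@@]1(C)O` differs from compound 3 in one group: fluoro in place of nitro on an aromatic carbon with fluoro in place of nitro on an aromatic carbon, ortho to a large group.

For the measured compounds named here, no measured step makes exactly this change. The closest is the modest 3.4-fold higher number from compound 2 to compound 3 (0.53 log units; beyond the scatter), where 4-fluorophenyl gives way to 2-nitrophenyl on a carbonyl carbon. Compound 4 carries 2-fluorophenyl, so it shares the fluoro of compound 2 and the place of the group in compound 3. Part of that step may therefore be undone, which points to a lower number.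

The expected size is a 1.9-fold lower number from compound 3 to compound 4 (0.29 log units; within the scatter) in this estimate.

For compound 4 the estimated value is 20000 nM, with an expected range of 9000 nM to 42000 nM.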

Compound 4, half-maximal inhibitory concentration: 28700 nM
Compound 4: the middle estimate sits 1.4-fold (0.16 log units) below what was measured; low and high end bracket the measured number.
By their numbers in this assay, from the lowest: compound 2; then compounds 4, 1 and 3 (each within the scatter of the next).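

In this assay, fluoro in place of nitro on this aromatic carbon, ortho to a large group, gives a 1.3-fold lower number from compound 3 to compound 4 (0.13 log units; within the scatter), so the two groups cannot be told apart here, and neither can the (2-fluorophenyl)carbonyl and benzyl groups on the oxygen, with a 1.0-fold lower number from compound 1 to compound 4 (0.01 log units; within the scatter). The clear difference comes instead from the place of the fluoro on the ring: 2-fluorophenyl in place of 4-fluorophenyl gives a 2.5-fold higher number from compound 2 to compound 4 (0.40 log units; beyond the scatter), which shows that fluoro alone does not bring the lower number of compound 2. No available evidence bears on what lies behind this result.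

On these data alone, whether other groups at this place would also stay within the scatter of compound 3 remains open, for instance an amine or a carboxylic acid. So does the effect of such groups in the place the fluoro holds in compound 2.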